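From Triazole to Pyrazole on a Shared Core

The source may hold more compounds than are shown below. What is called first, only, known or untested is meant among the compounds shown, and "the series" means these compounds.

Three measured compounds share one core and differ only in the group that ends a short saturated chain. Compound 1 `CCCCNc1nc(N)nc(C)c1CCCCc1ccccc1` carries a benzyl there and in an assay on HEK293 cells for agonist activity at Toll-like receptor 8 (Homo sapiens), read by spectrophotometry (on this read-out higher numbers stand for an effect only at larger amounts of compound and lower numbers for an effect already at smaller amounts), compound 1 gives 857 nM. Compound 2 `CCCCNc1nc(N)nc(C)c1CCCC(C)(C)O` gives 1220 nM, and compound 3 `CCCCNc1nc(N)nc(C)c1CCCn1cncn1` gives 1050 nM. On these numbers compound 3 stands second highest of the three, yet every step among them stays within the scatter: a 1.4-fold higher number from compound 1 to compound 2 (0.15 log units; within the scatter), a 1.2-fold higher number from compound 1 to compound 3 (0.09 log units; within the scatter) and a 1.2-fold lower number from compound 2 to compound 3 (0.07 log units; within the scatter).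

Compound 4 `CCCCNc1nc(N)nc(C)c1CCCn1cccn1` is not yet measured. It differs from compound 3 in one place: 1H-pyrazol-1-yl in place of 1H-1,2,4-triazol-1-yl on a saturated chain carbon, three bonds along the chain from an aromatic carbon. The core and the chain are untouched; only the small aromatic ring at the chain end changes, losing one nitrogen.

For the measured compounds named here, the steps that bear on this place are those from compound 1 to compound 3 and from compound 2 to compound 3, in which quite different groups were exchanged at the very same position, and neither moved the number beyond the scatter. A swap of one five-membered aromatic ring for a closely related one is a smaller change than either of those, so no step beyond the scatter is expected here. For compound 4 the expected step is a 1.1-fold lower number from compound 3 to compound 4 (0.02 log units; within the scatter). Compound 4 is therefore estimated at 1000 nM, with a range from 500 nM to 2000 nM.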

Compound 4, half-maximal effective concentration: 1050 nM
Estimate against measurement, compound 4: 1.1-fold (0.02 log units) below; low and high end bracket the measured number.
By their numbers in this assay, from the lowest: compounds 1, 3, 4 and 2 (each within the scatter of the next).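

Replacing 1H-1,2,4-triazol-1-yl with 1H-pyrazol-1-yl removes one ring nitrogen and one counted hydrogen-bond acceptor, while the ring size and heavy-atom count stay the same, and in this assay this exchange gives no change at the digits printed from compound 3 to compound 4 (within the scatter) at this place on the chain. The new ring also fits the picture set by the other end groups, with a 1.2-fold lower number from compound 2 to compound 4 (0.07 log units; within the scatter) and a 1.2-fold higher number from compound 1 to compound 4 (0.09 log units; within the scatter), so all four compounds now lie within the scatter of one another, and this flat picture holds for a closely matched pair of rings as well as for very different groups. No measurement is available to explain why the number stays so flat here.

The compounds shown do not reveal whether an end group of another kind, such as an amine or a carboxylic acid, would also stay within the scatter at this place. They also leave open whether a longer chain carrying the same 1H-pyrazol-1-yl would give a similar number, or whether the flat picture would hold with a different group on the shared core.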